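Swapping bromo for fluoro on a pyridine ring in a cytotoxicity series

A few compounds are considered here, and "the series" means these few. Any claim that something is new, unique, unknown or untested is made for them only; others in the source may bear on it.

Compounds measured so far:
- compound 1, `Nc1ccccc1NC(=O)c1ccc(NC(=S)NCc2cncc(Br)c2)cc1`, 7500 nM
- compound 2, `Nc1ccccc1NC(=O)c1ccc(CNC(=O)c2cc3cccnc3[nH]2)cc1`, 6100 nM
- compound 3, `Nc1ccccc1NC(=O)c1ccc(Cn2cc(-c3ccc(NC(=O)NCc4cccnc4)cc3)nn2)cc1`, 8100 nM

All three compounds were tested in a functional assay on HepG2 cells (Homo sapiens) for cytotoxicity, read by MTT assay, with a stated time of 72 h; a lower number here means a stronger inhibitor, a higher number a weaker inhibitor. Compound 1 gives 7500 nM, which is the second highest of the three numbers. Its nearest neighbour is compound 3 with 8100 nM, and the furthest is compound 2 with 6100 nM; both of these gaps fall within the usual scatter of repeated measurements, so the three values cannot be told apart.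

Compound 4 is `Nc1ccccc1NC(=O)c1ccc(NC(=S)NCc2cncc(F)c2)cc1`. It differs from compound 1 in a single place: fluoro in place of bromo on an aromatic carbon. The exchange happens on an aromatic carbon of a six-membered aromatic ring with one nitrogen, two atoms from the ring nitrogen. Going by the values given here, no pair of measured compounds shows this kind of exchange, so there is no step to lean on.

With so little to go on, the expectation for compound 4 in this assay is a step from compound 1 of a 1.1-fold higher number from compound 1 to compound 4 (0.03 log units; within the scatter), that is, none beyond the scatter. The estimated value for compound 4 is 8000 nM, with a range from 4000 nM to 16000 nM.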

Compound 4, half-maximal inhibitory concentration: 13000 nM
Compound 4: middle estimate off by 1.6-fold (0.21 log units), on the low side; the measured number falls inside the stated range.
By their numbers in this assay, from the lowest: compounds 2, 1, 3 and 4 (each within the scatter of the next, the first and the last beyond it).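

Going by these compounds alone, this is the first direct reading at this position of the pyridine ring: in this assay, fluoro in place of bromo gives a 1.7-fold higher number from compound 1 to compound 4 (0.24 log units; within the scatter), so this one exchange leaves the two compounds indistinguishable. Within the data shown here, the exchange swaps one heavy atom for one heavy atom, neither group counts as a hydrogen-bond donor or acceptor, and the rest of the molecule stays the same, so this pair isolates the halogen alone, which the earlier compounds, differing from one another in several places, could not do. No measurement of any property accompanies this pair, and nothing is at hand to interpret the step.

From the compounds shown here alone, what remains open is whether this position tolerates only a swap between these two halogens or a wider range of groups, since an amine, a carboxylic acid or a methoxy group in place of the bromo could give a step beyond the scatter. Going by these compounds, it is also open whether the same exchange would give a similar step on a different linker, such as a urea in place of the thiourea of compound 1.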